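A few compounds are considered here, and "the series" means these few. Any claim that something is new, unique, unknown or untested is made for them only; others in the source may bear on it.

Compound 1 `Nc1ccc(C#CC#Cc2cn([C@H]3C[C@H](O)[C@@H](CO)O3)c(=O)[nH]c2=O)cc1` in an ADME assay on HEL cells (Homo sapiens), read by cell counting, with a stated time of 3 days (a higher number here means that more compound is tolerated, a lower number that less compound is tolerated), gives > 100000 nM, which is a limit of the assay.
Compound 2 `O=c1[nH]c(=O)n([C@H]2C[C@H](O)[C@@H](CO)O2)cc1C#CC#Cc1ccc([N+](=O)[O-])cc1` gives 89000 nM.
Compound 3 `O=c1[nH]c(=O)n([C@H]2C[C@H](O)[C@@H](CO)O2)cc1C#CC#CCO` gives > 100000 nM, again a limit.

Compound 3 thus stands at the limit of > 100000 nM in this assay, at which 2 of the 3 values shown sit; its value is a limit, not a number. Compound 4 `O=c1[nH]c(=O)n([C@H]2C[C@H](O)[C@@H](CO)O2)cc1C#CC#CC1CC1` differs from it by cyclopropyl in place of hydroxymethyl on a triple-bonded carbon. Among the measured compounds shown here, two measured steps touch this position: an at least 1.1-fold higher number from compound 2 to compound 3 (0.05 log units; that floor lies within the scatter) and a step that the two limits leave unreadable from compound 1 to compound 3. Neither fixes a size for a change on the triple-bonded carbon, and no step beyond the scatter has been seen anywhere in the series. The step of a number no higher from compound 3 to compound 4 (the limit leaves the size open) is therefore expected to stay within the scatter. Compound 4 is estimated at 100000 nM, ranging from 50000 nM to 200000 nM, and is expected most likely to be reported again as a limit.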

Compound 4, half-maximal cytotoxic concentration: > 100000 nM
Compound 4: only a limit was reported; the forecaster's own chance of this, stated with the estimate: 70%; the middle value lies on the limit itself.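

In this assay compound 4 gives > 100000 nM, a limit, so cyclopropyl, with no hydrogen-bond donor, leaves the triple-bonded carbon as undifferentiated as hydroxymethyl did. Among the compounds shown here, the one readable step is an at least 1.1-fold higher number from compound 2 to compound 4 (0.05 log units; that floor lies within the scatter); the steps to compound 4 from compound 1 and compound 3 cannot be read. No step beyond the scatter has yet appeared, and the values gather at one limit: the limit of > 100000 nM in this assay, at which 3 of the 4 values shown sit.

As far as these compounds go, whether a carboxylic acid or a longer alkyl chain on the triple-bonded carbon would give a measurable number stays open. Any real size for a change at this position also remains unknown.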